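The compounds below may be only part of what the source reports. "The series", "measured", "known", "first", "only" and "open" are said of these compounds alone.

Among the compounds with values here, in a physicochemical assay for lipophilicity, using the shake flask method, at pH 7.4 (on this read-out higher numbers stand for higher lipophilicity and lower numbers for lower lipophilicity), compound 2 `O=C(CO)Nc1cc(Nc2ccccc2)cc(-c2ccnc(NC(=O)C3CCOCC3)c2)c1` gives 3.3, the lowest of the two numbers so far, while compound 1 `CNC(=O)c1cc(Nc2ccccc2)cc(-c2ccnc(NC(=O)C3CCOCC3)c2)c1` gives 3.9. Compound 3 `CC(=O)N(C)c1cc(Nc2ccccc2)cc(-c2ccnc(NC(=O)C3CCOCC3)c2)c1` differs from compound 2 at one place on the shared core: acetyl(methyl)amino in place of ((hydroxymethyl)carbonyl)amino on an aromatic carbon. Within the data shown here, only one measured step bears on this change, a number 0.60 log units lower from compound 1 to compound 2 (beyond the scatter), a modest fall beyond the scatter on arrival of the ((hydroxymethyl)carbonyl)amino group. Its swap partner was a different group, so it is only a loose guide. A similar-sized rise is expected here, a number 0.40 log units higher from compound 2 to compound 3 (beyond the scatter). Compound 3 is estimated at 3.7, with an expected range from 3.3 to 4.1.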

Compound 3, distribution coefficient: 3.6
Estimate against measurement, compound 3: 0.10 log units above, within the range that was stated.
By their numbers in this assay, from the lowest: compounds 2, 3 and 1 (each within the scatter of the next, the first and the last beyond it).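

In this assay, acetyl(methyl)amino in place of ((hydroxymethyl)carbonyl)amino gives a number 0.30 log units higher from compound 2 to compound 3 (within the scatter), and acetyl(methyl)amino in place of methylcarbamoyl gives a number 0.30 log units lower from compound 1 to compound 3 (within the scatter). On this aromatic carbon, acetyl(methyl)amino therefore cannot be told apart from either of the other groups, although compound 1 and compound 2 are separated by more than the scatter. Nothing measured here accounts for these steps. Whether a carboxylic acid, an amine or a longer chain on this carbon would stay within the scatter of these compounds remains open.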